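Bromo for hydrogen on the aryl of compound 2

This account rests on a few compounds, and the source may have more. Where it says the series, first, only, none or still open, it means among the compounds named here.

Two compounds of this series have a number in a functional assay on the whole organism for inhibition, with Rattus norvegicus as the target, read by paw edema, with a stated time of 1 h, at a dose of 50 mg/kg; a lower number here means less inhibition, a higher number more inhibition at the dose given (going by the name of the read-out). Compound 1 `CC(=O)c1c(NNc2cc(C)c3ccccc3n2)cc(C)oc1=O` gives 51.9% in this assay. Compound 2 `Cc1cc2nn(-c3ccccc3)c(C)c2c(=O)o1` gives 57% in this assay. The two numbers lie within the usual scatter of each other, so the data do not separate compound 2 from compound 1, and the inhibition in this assay is level between the pair. Compound 2 is the starting point for the next compound.

Compound 3 `Cc1cc2nn(-c3ccc(Br)cc3)c(C)c2c(=O)o1` has not yet been measured in this assay. It differs from compound 2 in one place: bromo in place of hydrogen on an aromatic carbon. The bromo sits para to a large group on a six-membered aromatic ring of carbon only; nothing else in the structure is touched.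

Among the measured compounds shown here, no pair of measured compounds shows the effect of a single change, so there is no measured step to lean on. The expectation is therefore a step of no more than the scatter, in either direction, and the estimated step of no change at the digits printed from compound 2 to compound 3 (within the scatter) is accordingly taken as flat. Compound 3 is expected to give about 57% in this assay, estimated to fall between 42% and 70%.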

Compound 3, a percentage reported as inhibition, in the whole organism at one dose (the size of the read-out at that dose, not a potency): 59.5%
For compound 3 the middle estimate is 2.5 percentage points below the measured one, within the range that was stated.
By their numbers in this assay, from the lowest: compounds 1, 2 and 3 (each within the scatter of the next).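

In this assay, among the compounds shown here, the series now has its first reading of a single change, a number 2.5 percentage points higher from compound 2 to compound 3 (within the scatter), and this is the first direct information on the position para to a large group on the six-membered aromatic ring of carbon only. At the one dose and time tested, bromo in place of hydrogen there leaves the inhibition level with that of the parent, so the data do not order the pair and this aromatic carbon can carry the added heavy atom with inhibition retained. No measurement available here bears on the reason for this result.

Still open, from the compounds shown here alone, is whether a different kind of group on the same aromatic carbon, such as an amine, a carboxylic acid or a longer chain, would give a step beyond the scatter, or whether the level reading is particular to bromo. Also open, going by these compounds, is whether compound 2 and compound 3 would stay level at other doses, since a single-dose percentage gives the size of the read-out at that dose and not a potency.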